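Iodo to furanyl on the shared core: antiproliferative notes

The source may report more compounds than this note shows. Statements on the series, on what has been measured and on what is new or still open speak of the compounds shown alone.

Measured so far in a functional assay on HepG2 cells (Homo sapiens) for antiproliferative activity, read by XTT assay, with a stated time of 72 h; a lower number here means a stronger inhibitor, a higher number a weaker inhibitor:
compound 1 `Nc1nc(N)c2c(-c3cc4ccccc4o3)cn([C@@H]3O[C@H](CO)[C@@H](O)[C@H]3O)c2n1`: compound 1 gives > 20000 nM, a limit of the assay.
compound 2 `COc1ncnc2c1c(I)cn2[C@@H]1O[C@H](CO)[C@@H](O)[C@H]1O`: compound 2 gives > 20000 nM, a limit.
compound 3 `CNc1ncnc2c1c(-c1ccccc1)cn2[C@@H]1O[C@H](CO)[C@@H](O)[C@H]1O`: compound 3 gives > 20000 nM, a limit.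

Compound 2 therefore stands at the same point as every other value shown, (the limit of > 20000 nM in this assay, at which 3 of the 3 values shown sit). No pair of these compounds differs in one place, so no measured step can be quantified, and nothing distinguishes them in this assay .

Compound 4 `COc1ncnc2c1c(-c1ccco1)cn2[C@@H]1O[C@H](CO)[C@@H](O)[C@H]1O` differs from compound 2 by furan-2-yl in place of iodo on an aromatic carbon. The expected step in this assay is a step that the limit leaves unreadable from compound 2 to compound 4, that is, no change beyond the scatter, the limit most likely being reported again. Compound 4 is estimated at 40000 nM, with a range from 10000 nM to 200000 nM.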

Compound 4, half-maximal inhibitory concentration: 300 nM
Estimate against measurement, compound 4: 130-fold (2.12 log units) above; measured number below the stated range.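

In this assay, the aromatic carbon two ring bonds from the ring nitrogen carries a change that can be read: furan-2-yl in place of iodo gives an at least 66-fold lower number from compound 2 to compound 4 (1.82 log units; beyond the scatter). This is the first quantifiable step in the series, and compound 4 is the only compound shown whose value is not a limit. The step is itself only a bound, since its starting point is a limit: the limit of > 20000 nM in this assay, at which 3 of the 4 values shown sit.

From the compounds shown here alone, whether a thiophene ring or an amine at this carbon would give a similar number remains open. Also open, going by these compounds, is whether furan-2-yl needs the methoxy group on the shared core.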